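Aryl-ether to methyl ether at the pyridine oxygen

The compounds below may be only part of what the source reports. "The series", "measured", "known", "first", "only" and "open" are said of these compounds alone.

Measured so far:
compound 1 `COc1ccccc1Oc1cncc(C2=CC3CNCC(C2)C3)c1`, 1 nM
compound 2 `FC(F)(F)c1cncc(C2=CC3CNCC(C2)C3)c1`, 0.7 nM
compound 3 `COc1ccc(Oc2cncc(C3=CC4CNCC(C3)C4)c2)cc1`, 1.4 nM

All three numbers come from an in vitro assay on SH-EP1 cells for displacement of a labelled ligand from Neuronal acetylcholine receptor; alpha4/beta2 (Homo sapiens); on this read-out higher numbers stand for weaker inhibition and lower numbers for stronger inhibition. Compound 3 does not separate from its neighbours on this read-out: its number lies within the scatter of compound 1 and of compound 2, so no order among the three can be read. Going by the values given here, the one measured step that bears on compound 3 is a 1.4-fold higher number from compound 1 to compound 3 (0.15 log units; within the scatter), which is within the scatter and shows that moving the methoxy group around the pendant ring leaves the number essentially untouched.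

Compound 4 `COc1cncc(C2=CC3CNCC(C2)C3)c1` is not yet measured. It differs from compound 3 as methyl in place of 4-methoxyphenyl on an oxygen on an aromatic ring. Among the compounds with values here, no measured pair tests removal of the whole pendant ring, so the step cannot be read off directly. Compound 2, carrying only a trifluoromethyl in that position, gives 0.7 nM, which suggests a large group on the oxygen is not needed for a low number. Compound 4 is therefore expected near the others, with an estimated step of a 1.4-fold higher number from compound 3 to compound 4 (0.15 log units; within the scatter) that is not beyond the scatter. The estimate for compound 4 is 2 nM, with a range from 0.7 nM to 6 nM.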

Compound 4, inhibition constant: 0.3 nM
The estimate for compound 4 lay 6.7-fold (0.82 log units) above the measured number; the whole stated range lies above it.
By their numbers in this assay, from the lowest: compound 4; then compounds 2, 1 and 3 (each within the scatter of the next).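

In this assay the pendant aryl ring on the oxygen is not needed for a low number: methyl in place of 4-methoxyphenyl gives a 4.7-fold lower number from compound 3 to compound 4 (0.67 log units; beyond the scatter) and methyl in place of 2-methoxyphenyl gives a 3.3-fold lower number from compound 1 to compound 4 (0.52 log units; beyond the scatter) even though moving the methoxy group around that ring changed nothing beyond the scatter. The group at this place on the shared core also matters among the compounds without a pendant ring, as methoxy in place of trifluoromethyl gives a 2.3-fold lower number from compound 2 to compound 4 (0.37 log units; beyond the scatter) and this step too lies beyond the scatter. No evidence at hand accounts for these steps.

Going by these compounds, whether the low number holds with a longer chain on the oxygen, such as ethyl or propyl, remains open. Also open, on these data alone, is whether the oxygen itself is required, a question that an amine at this place would address.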